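Dropping the methyl from compound 1: an expected small shift

The source may hold more compounds than are shown below. What is called first, only, known or untested is meant among the compounds shown, and "the series" means these compounds.

Compound 1 `Cc1ccc2nc(Nc3nc4ccccc4s3)sc2c1` was tested in a functional assay on THP-1 cells (Homo sapiens) for cytotoxicity, read by MTT assay, with a stated time of 48 h (a lower number here means a stronger inhibitor, a higher number a weaker inhibitor), where compound 1 gives 34200 nM. Among the two plain numbers shown, compound 1 has the higher one, with compound 3 `Fc1ccc2nc(NC(=S)Nc3ccc(Cl)cc3)sc2c1` close by: in this assay compound 3 gives 31200 nM, a difference within the usual scatter, so the two cannot be told apart. Compound 2 `Cc1ccc2nc(Nc3nc4ccc(F)cc4s3)sc2c1` reached only a limit of the assay, as in this assay compound 2 gives > 50000 nM. Among the compounds with values here, the one single-point change measured here, an at least 1.4-fold higher number from compound 1 to compound 2 (0.16 log units; that floor lies within the scatter), sits at a floor within the scatter and therefore gives little guidance on its own.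

Compound 4 `c1ccc2sc(Nc3nc4ccccc4s3)nc2c1` differs from compound 1 by hydrogen in place of methyl on an aromatic carbon. Within the data shown here, no measured step removes a methyl, so the expectation rests on compound 1 standing at 34200 nM and on the small size of an at least 1.4-fold higher number from compound 1 to compound 2 (0.16 log units; that floor lies within the scatter). The step is expected to be a 1.2-fold higher number from compound 1 to compound 4 (0.07 log units; within the scatter), within the scatter. In this assay compound 4 is estimated at 40000 nM, with a range from 15000 nM to 110000 nM.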

Compound 4, half-maximal inhibitory concentration: 28800 nM
Beside the measured number, compound 4's estimate is 1.4-fold (0.14 log units) above it, and the stated range covers the measured number.
By their numbers in this assay, from the lowest: compounds 4, 3 and 1 (each within the scatter of the next). At a limit, above all of these: compound 2.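

In this assay, within the data shown here, the first step with a number at both ends at this place, on an aromatic carbon meta to a fused ring and para to a fused ring, is a 1.2-fold lower number from compound 1 to compound 4 (0.07 log units; within the scatter). Methyl and hydrogen at this place therefore cannot be told apart, so the methyl of compound 1 shows no measurable contribution to the cytotoxicity read here. This step has a firm size, whereas the fluoro change in compound 2 gives only a floor, as its value is a limit: the limit of > 50000 nM in this assay, at which 1 of the 4 values shown sits.

On these data alone, it remains open whether a different group at this place, such as a methoxy, an amine or a carboxylic acid, would shift the number beyond the scatter. As far as these compounds go, it is also open whether any change to the shared core would yield a clearly stronger inhibitor in this assay.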